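Shifting a Methyl Group on the Phenyl Ring of Compound 3

This account rests on a few compounds, and the source may have more. Where it says the series, first, only, none or still open, it means among the compounds named here.

Three compounds have been measured in a functional assay on A549 cells (Homo sapiens) for antiproliferative activity, read by MTT assay, with a stated time of 48 h; on this read-out higher numbers stand for weaker inhibition and lower numbers for stronger inhibition:
compound 1 `CCOc1ccc(-n2nncc2CN2C(=O)C3(C(C#N)=C(N)Oc4c3c3nc5ccccc5nc3c3ccccc43)c3ccccc32)cc1` gives 25200 nM
compound 2 `N#CC1=C(N)Oc2c(c3nc4ccccc4nc3c3ccccc23)C12C(=O)N(Cc1cnnn1-c1ccc(S(N)(=O)=O)cc1)c1ccccc12` gives only a limit of the assay, > 50000 nM
compound 3 `Cc1ccccc1-n1nncc1CN1C(=O)C2(C(C#N)=C(N)Oc3c(N)cc4nc5ccccc5nc4c32)c2ccccc21` gives 31700 nM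

Compound 3 stands highest of the two numbers, and compound 1 lies within the scatter of it. Compound 4 `Cc1cccc(-n2nncc2CN2C(=O)C3(C(C#N)=C(N)Oc4c(N)cc5nc6ccccc6nc5c43)c3ccccc32)c1` differs from compound 3 by 3-methylphenyl in place of 2-methylphenyl on an aromatic nitrogen. Among the compounds with values here, the single measured step, an at least 1.9-fold higher number from compound 1 to compound 2 (0.29 log units; that floor lies within the scatter), alters a different part of the molecule and reaches only a floor within the scatter, so it offers no guide to moving a methyl group. Nothing measured points to a change beyond the scatter, and compound 4 is therefore expected to show a 1.0-fold higher number from compound 3 to compound 4 (0.00 log units; within the scatter) in this assay. The estimate for compound 4 is 32000 nM, between 12000 nM and 80000 nM.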

Compound 4, half-maximal inhibitory concentration: 12300 nM
Beside the measured number, compound 4's estimate is 2.6-fold (0.42 log units) above it; measured number inside the range.
By their numbers in this assay, from the lowest: compound 4; then compounds 1 and 3 (each within the scatter of the next). At a limit, above all of these: compound 2.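

In this assay, the place of a single methyl group on the phenyl ring carried by the aromatic nitrogen matters: 3-methylphenyl in place of 2-methylphenyl gives a 2.6-fold lower number from compound 3 to compound 4 (0.41 log units; beyond the scatter). This is the first step shown that clearly exceeds the scatter, and it comes with no change in the atoms present. Nothing available explains why this shift changes the number.

As far as these compounds go, it remains open whether an ethyl group, a chlorine atom or an amine in place of that methyl group would lower the number further. Also open, from the compounds shown here alone, is whether the same shift would give a similar step on the core of compound 1.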